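This account rests on a few compounds, and the source may have more. Where it says the series, first, only, none or still open, it means among the compounds named here.

Compound 1 `[SeH]c1nc([SeH])c2ccccc2n1` gives 5980 nM in a functional assay on HTB-54 cells (Homo sapiens) for cytotoxicity, read by MTT assay, with a stated time of 72 h; a higher number here means a weaker inhibitor of growth, a lower number a stronger inhibitor of growth. Compound 2 `Nc1nc([SeH])nc2ncccc12` gives 44300 nM. Compound 3 `[SeH]c1nc([SeH])c2cccnc2n1` gives 4030 nM.

Compound 1 and compound 3 have values within the usual scatter of each other, while compound 2 gives a clearly higher number than compound 1. Compound 3 carries the change one nitrogen atom in place of one selenium atom, on an aromatic carbon to give compound 2, and that step was an 11-fold higher number from compound 3 to compound 2 (1.04 log units; beyond the scatter). The difference between the two cores of compound 1 and compound 3 is not broken down here. Compound 4 `Nc1nc([SeH])nc2ccccc12` is not yet measured; it arises from compound 1 by one nitrogen atom in place of one selenium atom, on an aromatic carbon, the same change in the same place. Because the step of an 11-fold higher number from compound 3 to compound 2 (1.04 log units; beyond the scatter) was large, compound 4 is expected to show a step of an 8.4-fold higher number from compound 1 to compound 4 (0.92 log units; beyond the scatter). Compound 4 is therefore estimated at 50000 nM, between 15000 nM and 150000 nM.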

Compound 4, concentration for 50% growth inhibition: 40 nM
Compound 4: middle estimate off by 1300-fold (3.10 log units), on the high side; measured number outside the range, below it.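

In this assay the exchange of one selenium atom for an amino group gave a 150-fold lower number from compound 1 to compound 4 (2.17 log units; beyond the scatter). Set beside the same exchange on the core of compound 3, the step runs in the opposite direction, so the outcome of this change depends on the core that carries it: the same change on two cores in this assay, an 11-fold higher number (1.04 log units; beyond the scatter) from compound 3 to compound 2 and a 150-fold lower number (2.17 log units; beyond the scatter) from compound 1 to compound 4, 1600-fold (3.22 log units) apart, beyond the scatter of two such steps With only two pairs, this shows that a step seen on one of these cores cannot simply be carried to the other, but it does not show which feature of the cores is responsible or how the change would behave on any further core.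

The compounds shown leave open whether a methylamino, dimethylamino or hydroxyl group at the same place would give a number close to that of compound 4. Also open, on these data alone, is what a thiol or a methyl group in place of the remaining selenium atom would do on either core.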